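The source may hold more compounds than are shown below. What is called first, only, known or untested is meant among the compounds shown, and "the series" means these compounds.

Measured so far in a functional assay on A-375 cells (Homo sapiens) for antiproliferative activity; on this read-out higher numbers stand for weaker inhibition and lower numbers for stronger inhibition:
- Compound 1 `O=C(Nc1ccc(-c2ccccn2)cc1)C1CCCN(Cc2ccc(F)c(F)c2)C1`: 9000 nM
- Compound 2 `O=C(Nc1ccc(-c2ncc[nH]2)cc1)C1CCCN(Cc2ccc(F)c(F)c2)C1`: 19000 nM
- Compound 3 `O=C(Nc1ccc(-c2ccn[nH]2)cc1)C1CCCN(Cc2ccc(F)c(F)c2)C1`: 520 nM

Compound 3 gives the lowest number of the three, and its steps to both other compounds lie beyond the scatter. Compound 4 `O=C(Nc1ccc(-c2cccs2)cc1)C1CCCN(Cc2ccc(F)c(F)c2)C1` keeps the shared core and alters one group: thiophen-2-yl in place of 1H-pyrazol-5-yl on an aromatic carbon. Going by the values given here, no measured step makes this exact swap, so the evidence is indirect.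

Two large steps bear on it: a 17-fold lower number from compound 1 to compound 3 (1.24 log units; beyond the scatter) and a 37-fold lower number from compound 2 to compound 3 (1.56 log units; beyond the scatter). In both, 1H-pyrazol-5-yl takes the place of another group and the number falls sharply. Read in reverse, they show that both groups tried in place of 1H-pyrazol-5-yl gave much higher numbers. The remaining step, a 2.1-fold higher number from compound 1 to compound 2 (0.32 log units; beyond the scatter), is modest, so those two replacements differ far less from each other than either does from compound 3.

Thiophen-2-yl itself is untested, and three compounds cannot show how it will compare. A clear rise in the number is still the likelier outcome, probably a large one. The expected change is a 5.8-fold higher number from compound 3 to compound 4 (0.76 log units; beyond the scatter). Compound 4 is estimated at 3000 nM, with an expected range from 700 nM to 13000 nM.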

Compound 4, half-maximal inhibitory concentration: 390 nM
Compound 4: middle estimate off by 7.7-fold (0.89 log units), on the high side; the whole stated range lies above it.
By their numbers in this assay, from the lowest: compounds 4 and 3 (each within the scatter of the next); then compound 1; then compound 2.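

In this assay, thiophen-2-yl in place of 1H-pyrazol-5-yl on an aromatic carbon para to a large group gives a 1.3-fold lower number from compound 3 to compound 4 (0.12 log units; within the scatter), so a low number at this position is not confined to 1H-pyrazol-5-yl and persists without that group's hydrogen-bond donor or its nitrogens. Thiophen-2-yl also stands well apart from the other two groups, with a 49-fold lower number from compound 2 to compound 4 (1.69 log units; beyond the scatter) and a 23-fold lower number from compound 1 to compound 4 (1.36 log units; beyond the scatter), which places compound 3 and compound 4 together, clearly below compound 1 and compound 2. Ring size alone does not sort these compounds, as compound 2 carries a five-membered aromatic ring yet gives the highest number of the four, and no measurement shown explains why these groups divide as they do.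

Still open, as far as these compounds go, is whether a plain phenyl or a furan-2-yl group at this position would join compound 3 and compound 4 or fall with compound 1 and compound 2. From the compounds shown here alone, it is also open whether a small substituent such as methyl or chlorine on the thiophen-2-yl ring would leave the number unchanged.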